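This account rests on a few compounds, and the source may have more. Where it says the series, first, only, none or still open, it means among the compounds named here.

Measured in a functional assay on DU-145 cells (Homo sapiens) for inhibition, read by trypan blue exclusion, with a stated time of 96 h; a higher number here means a weaker inhibitor of growth, a lower number a stronger inhibitor of growth:
- compound 1 `Cc1ccc(CS/C(=C/c2ccc(O)cc2)C(=O)c2ccc(Cl)cc2)cc1`: 10000 nM
- compound 2 `Cc1ccc(CS/C(=C/c2sccc2C)C(=O)c2ccc(Cl)cc2)cc1`: 10000 nM
- compound 3 `COc1ccccc1/C=C(/SCc1ccc(C)cc1)C(=O)c1ccc(Cl)cc1`: 10000 nM

Level with compound 1 and compound 2, compound 3 stands at 10000 nM. The next compound, compound 4 `Cc1ccc(CS/C(=C/c2cc([N+](=O)[O-])ccc2F)C(=O)c2ccc(Cl)cc2)cc1`, has 2-fluoro-5-nitrophenyl in place of 2-methoxyphenyl on a double-bonded chain carbon bound to a double-bonded chain carbon.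

Within the data shown here, three measured steps bear on this change, all made at the same place: no change at the digits printed from compound 1 to compound 2 (within the scatter), no change at the digits printed from compound 1 to compound 3 (within the scatter) and no change at the digits printed from compound 2 to compound 3 (within the scatter). None of the three replacements moved the value. A further replacement at this place is therefore expected to give no step beyond the scatter in this assay. However, no measured compound carries the 2-fluoro-5-nitrophenyl group, so the expectation is loose, and the range reaches further towards stronger inhibition than towards weaker.

The expected step is a 1.4-fold lower number from compound 3 to compound 4 (0.15 log units; within the scatter). For compound 4 the estimated value is 7000 nM, with an expected range of 1500 nM to 12000 nM.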

Compound 4, concentration for 50% growth inhibition: 1000 nM
Compound 4: middle estimate off by 7.0-fold (0.85 log units), on the high side; measured number outside the range, below it.
By their numbers in this assay, from the lowest: compound 4; then compounds 1, 2 and 3 (each within the scatter of the next).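

In this assay this position proved able to move the value after all: 2-fluoro-5-nitrophenyl in place of 2-methoxyphenyl gives a 10-fold lower number from compound 3 to compound 4 (1.00 log units; beyond the scatter) and the same group gives a 10-fold lower number from compound 2 to compound 4 (1.00 log units; beyond the scatter) in place of 3-methylthiophen-2-yl and a 10-fold lower number from compound 1 to compound 4 (1.00 log units; beyond the scatter) in place of 4-hydroxyphenyl. The three earlier groups stand level with one another, so compound 4 alone separates from the set, and this single compound carries the whole difference. Nothing at hand gives a reason for this step.

The compounds shown do not tell whether the fluorine or the nitro group carries the step, as the two occur only together, and a phenyl bearing either one alone would separate them. From the compounds shown here alone, whether an amine in place of the nitro group keeps the lower number also remains open.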